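Urea in place of amide on the valine nitrogen

The source may report more compounds than this note shows. Statements on the series, on what has been measured and on what is new or still open speak of the compounds shown alone.

The study concerns two measured compounds and one yet to be tested. Compound 1 `Cc1ccccc1C(=O)N[C@@H](C(=O)N1CCC(c2ccc(Cl)cc2)CC1)C(C)C` gives 32 nM in an assay on THP-1 cells for displacement of a labelled ligand from C-C chemokine receptor type 1 (Homo sapiens); a higher number here means a weaker inhibitor, a lower number a stronger inhibitor. Compound 2 `CC(C)[C@@H](NC(=O)CCc1ccc(F)cc1)C(=O)N1CCC(c2ccc(Cl)cc2)CC1` gives 70 nM in this assay, the higher of the two numbers; the step of a 2.2-fold higher number from compound 1 to compound 2 (0.34 log units; beyond the scatter) separates them. Compound 3 `CC(C)[C@@H](NC(=O)NCc1ccccc1)C(=O)N1CCC(c2ccc(Cl)cc2)CC1` has not yet been measured. It differs from compound 2 by benzylamino in place of 2-(4-fluorophenyl)ethyl on a carbonyl carbon. Going by the values given here, only one measured step bears on this change: it sits on the same carbonyl carbon and was modest, a 2.2-fold higher number from compound 1 to compound 2 (0.34 log units; beyond the scatter). Among the compounds with values here, no measured compound carries a urea-type nitrogen at that place, so there is no direct precedent for the direction of the new step. Within the data shown here, the account therefore treats it as expected to be of similar size to the one known step, with either direction open, and puts its weight on a number close to that of compound 2. For compound 3 the value in this assay is estimated at 70 nM, between 25 nM and 200 nM. The expected step of no change at the digits printed from compound 2 to compound 3 (within the scatter) is thus small, with the range allowing a move beyond the scatter either way.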

Compound 3, half-maximal inhibitory concentration: 180 nM
For compound 3 the middle estimate is 2.6-fold (0.41 log units) below the measured one; low and high end bracket the measured number.
By their numbers in this assay, from the lowest: compound 1; then compound 2; then compound 3.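

The result gives this position its first measured case of a urea-type nitrogen: in this assay, benzylamino on the carbonyl carbon gives a 2.6-fold higher number from compound 2 to compound 3 (0.41 log units; beyond the scatter), a step in the same direction as the earlier one and of similar size. Set against 2-methylphenyl, the same group gives a 5.6-fold higher number from compound 1 to compound 3 (0.75 log units; beyond the scatter), the widest gap among the three compounds, so this carbonyl carbon responds measurably to each of the three groups placed on it, and benzylamino carries the highest number of the three. Nothing available explains why the numbers at this position run in this order.

The step from 2-(4-fluorophenyl)ethyl to benzylamino changes the chain, the fluorine and the nitrogen together, so the compounds shown do not separate what each of these contributes to the higher number. On these data alone, it remains open how a plain 2-phenylethyl, a 2-phenylethylamino or an anilino group on the same carbonyl carbon would read, and whether any urea at this place can reach the number of the amide in compound 1.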